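A few compounds are considered here, and "the series" means these few. Any claim that something is new, unique, unknown or untested is made for them only; others in the source may bear on it.

Measured compounds:
- compound 1, `Cc1cc(O)c(C(=O)/C=C/c2ccccc2)c(-c2ccccc2)c1C(=O)/C=C/c1ccccc1`, gives 10000 nM in a functional assay on MCF7 cells (Homo sapiens) for cytotoxicity, read by MTT assay, with a stated time of 24 h; on this read-out lower numbers stand for stronger inhibition and higher numbers for weaker inhibition
- compound 2, `Cc1cc(O)c(C(=O)/C=C/c2cccc3ccccc23)c(-c2ccccc2)c1C(=O)/C=C/c1cccc2ccccc12`, gives 30000 nM in this assay
- compound 3, `Cc1cc(O)c(C(=O)/C=C/c2ccc(Cl)cc2)c(-c2ccc(Br)cc2)c1C(=O)/C=C/c1ccc(Cl)cc1`, gives 20000 nM in this assay

Among these three numbers, compound 1 has the lowest. Its gap to compound 3 lies within the usual scatter of repeated measurements, so the two cannot be told apart; its gap to compound 2 lies beyond the scatter, so compound 2 does show a weaker effect than compound 1.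

Compound 4, `Cc1cc(O)c(C(=O)/C=C/c2ccccc2)c(-c2ccc(OCc3ccccc3)cc2)c1C(=O)/C=C/c1ccccc1`, has not yet been measured. Compared with compound 1 the change is benzyloxy in place of hydrogen on an aromatic carbon. Going by the values given here, no pair of measured compounds differs by exactly this kind of change, so there is nothing to read the size of the step from directly. The three measured compounds all sit in a narrow band, and none of their differences points to a strong effect of substituents on the shared core. The step from compound 1 to compound 4 in this assay is therefore expected to be small, a 1.2-fold higher number from compound 1 to compound 4 (0.08 log units; within the scatter), in neither direction beyond the scatter. Compound 4 is estimated at 12000 nM, with a range from 3000 nM to 50000 nM.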

Compound 4, half-maximal inhibitory concentration: "not active" (no number reported)
Compound 4: no number reported; the estimate stays without a comparison.
By their numbers in this assay, from the lowest: compounds 1, 3 and 2 (each within the scatter of the next, the first and the last beyond it).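

Going by these compounds alone, compound 4 is reported as "not active" in this assay with no number, so no step from compound 1 to compound 4 can be read. No evidence on this result is available. Going by these compounds, how far benzyloxy in place of hydrogen shifts the number remains open.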